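The source may report more compounds than this note shows. Statements on the series, on what has been measured and on what is new or still open speak of the compounds shown alone.

Measured so far:
- compound 1 `O=C(Nc1ccc(F)cc1)Nc1cccc(CNc2ncnc3ccccc23)c1`: 44300 nM
- compound 2 `O=C(Nc1ccc([N+](=O)[O-])cc1)Nc1cccc(CNc2ncnc3ccccc23)c1`: 9420 nM
- compound 3 `COc1ccc(NC(=O)Nc2cccc(CNc3ncnc4cc(OC)c(OC)cc34)c2)cc1`: 12300 nM

In a functional assay on MGC-803 cells (Homo sapiens) for antiproliferative activity, read by MTT assay (on this read-out lower numbers stand for stronger inhibition and higher numbers for weaker inhibition), compound 3 stands second highest of the three numbers. Its nearest neighbour is compound 2, which lies within the scatter of it, while compound 1 sits beyond the scatter on the higher side. Compound 4 `COc1cc2ncnc(NCc3cccc(NC(=O)Nc4cccc(C(F)(F)F)c4)c3)c2cc1OC` differs from compound 3 in one place: 3-(trifluoromethyl)phenyl in place of 4-methoxyphenyl on an amide-type nitrogen. For the measured compounds named here, no measured pair carries exactly this change. Going by the values given here, the only step that touches the same region is a 4.7-fold lower number from compound 1 to compound 2 (0.67 log units; beyond the scatter), where the substituent on the phenyl ring at the far end of the urea was exchanged on a core without the two methoxy groups that compound 3 and compound 4 share. As far as these compounds go, that step shows that changes on this ring can move the number, but its direction for the present exchange is unknown. The expectation is therefore a small step, a 1.5-fold lower number from compound 3 to compound 4 (0.19 log units; within the scatter), leaning towards a lower number. Compound 4 is estimated at 8000 nM, with a range from 2500 nM to 30000 nM.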

Compound 4, half-maximal inhibitory concentration: > 50000 nM
Compound 4 gave a limit, no number (the forecaster's own chance of this, stated with the estimate: 5%); middle value at least 6.2-fold (0.79 log units) from the limit.
By their numbers in this assay, from the lowest: compounds 2 and 3 (each within the scatter of the next); then compound 1. At a limit, above all of these: compound 4.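

In this assay, replacing 4-methoxyphenyl with 3-(trifluoromethyl)phenyl on the amide-type nitrogen gives an at least 4.0-fold higher number from compound 3 to compound 4 (0.60 log units; beyond the scatter). For the compounds shown here, the only earlier step on this ring, a 4.7-fold lower number from compound 1 to compound 2 (0.67 log units; beyond the scatter), went towards a lower number on a core without the two methoxy groups, whereas this one shows that a change here can also push the number clearly upward on the core shared by compound 3 and compound 4. The reading for compound 4 is a limit of the assay, not a number, so only the lower bound of this step is known: the limit of > 50000 nM in this assay, at which 1 of the 4 values shown sits.

This exchange alters both the group on the ring and its place, and the compounds shown do not separate the two. They also do not tell what an amine or a carboxylic acid on this ring would do to the number.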